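Swapping the Amine Ring for a Branched Chain

The source may hold more compounds than are shown below. What is called first, only, known or untested is meant among the compounds shown, and "the series" means these compounds.

Of the compounds shown here, three have been tested in a functional assay on EA.hy 926 cells (Homo sapiens), read by fluorescence, tested at 1 uM; a lower number here means a weaker effect, a higher number a stronger effect of the compound at the concentration tested. Compound 1 `COc1cc(/C=C/C(=O)/C=C(/C=C/c2ccc(OC(C)=O)c(OC)c2)NC2CCCCC2)ccc1OC(C)=O` gives 101%, the second highest of the three. Compound 2 `CCCNC(=C\C(=O)/C=C/c1ccc(O)c(OC)c1)/C=C/c1ccc(O)c(OC)c1` gives 78%, and compound 3 `C=CCNC(=C\C(=O)/C=C/c1ccc(O)c(OC)c1)/C=C/c1ccc(O)c(OC)c1` gives 124%. For the measured compounds named here, the only step between close neighbours is a number 46 percentage points higher from compound 2 to compound 3 (beyond the scatter). Compound 4 `COc1cc(/C=C/C(=O)/C=C(/C=C/c2ccc(OC(C)=O)c(OC)c2)NCC(C)C)ccc1OC(C)=O` differs from compound 1 in one place: isobutyl in place of cyclohexyl on an amine nitrogen. Going by the values given here, no measured step touches the group on the amine nitrogen, and the one known step concerns a different part of the shared core, so it gives no guide to the direction here. Compound 4 is therefore expected to land close to compound 1, with a wide range; the expected step is a number 6 percentage points lower from compound 1 to compound 4 (within the scatter). The estimate for compound 4 in this assay is 95%, with a range from 60% to 130%.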

Compound 4, a percentage reported as activity, at one concentration (the size of the read-out at that concentration, not a potency): 104%
Compound 4: the middle estimate sits 9 percentage points below what was measured, within the range that was stated.
By their numbers in this assay, from the lowest: compound 2; then compounds 1 and 4 (each within the scatter of the next); then compound 3.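

The step of a number 3 percentage points higher from compound 1 to compound 4 (within the scatter) in this assay comes with isobutyl in place of cyclohexyl on the amine nitrogen. For the compounds shown here, this is the first measured step at this group, and it shows that, on this core, an open chain of 4 carbons can replace the ring of 6 carbons without a change beyond the scatter. Nothing available explains this result.

On these data alone, whether a phenyl ring, a longer chain or a carboxylic acid would do the same on this nitrogen remains open. So does whether the swap from cyclohexyl to isobutyl behaves alike on the core with free hydroxyl groups.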